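A few compounds are considered here, and "the series" means these few. Any claim that something is new, unique, unknown or untested is made for them only; others in the source may bear on it.

Measured compounds in a functional assay on B16-F10 cells (Mus musculus) for cytotoxicity, read by MTT assay, with a stated time of 48 h; on this read-out higher numbers stand for weaker inhibition and lower numbers for stronger inhibition:
compound 1 `O=C(/C=C\Nc1ccc(F)cc1)c1nc(-c2ccc(F)cc2)n2ccccc12` — > 30000 nM
compound 2 `COc1ccc(N/C=C\C(=O)c2nc(-c3ccc(C(F)(F)F)cc3)n3ccccc23)cc1OC` — > 30000 nM
compound 3 `O=C(/C=C\Nc1ccc2cc[nH]c2c1)c1nc(-c2ccc(C(F)(F)F)cc2)n2ccccc12` — > 30000 nM

Compound 1 gives only a limit of the assay, > 30000 nM, and no number in this assay. Compound 2 likewise sits at a limit, > 30000 nM. Compound 3 also reaches only a limit, > 30000 nM. Among the measured compounds shown here, the single measured step between neighbours, a step that the two limits leave unreadable from compound 2 to compound 3, is therefore not readable in size or direction, and the limit of > 30000 nM in this assay, at which 3 of the 3 values shown sit, shows that every value shown so far sits at that same limit.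

Compound 4 `COc1ccc(N/C=C\C(=O)c2nc(-c3ccc(F)cc3)n3ccccc23)cc1` differs from compound 1 by methoxy in place of fluoro on an aromatic carbon. For the measured compounds named here, no measured step bears directly on this exchange, and the one step that exists, a step that the two limits leave unreadable from compound 2 to compound 3, cannot be sized. The expectation for compound 4 is built only on compound 1, whose value is a limit, > 30000 nM, so compound 4 is expected to stay at or near that limit as well. The step from compound 1 to compound 4 is thus estimated as a number no higher from compound 1 to compound 4 (the limit leaves the size open), with no change beyond the scatter anticipated. Compound 4 is estimated at 30000 nM in this assay, with a range from 10000 nM to 100000 nM, and most likely the assay will again report only a limit.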

Compound 4, half-maximal inhibitory concentration: 2560 nM
Beside the measured number, compound 4's estimate is 12-fold (1.07 log units) above it; the whole stated range lies above it.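

Going from (4-fluorophenyl)amino to (4-methoxyphenyl)amino, with the rest of the molecule unchanged, gives the first readable step in this assay, an at least 11-fold lower number from compound 1 to compound 4 (1.06 log units; beyond the scatter). From the compounds shown here alone, this shows that the group on this aromatic carbon matters in this assay, as one exchange of fluoro for methoxy is enough to bring compound 4 to a measured number, although the true size of the step stays open, as compound 1 has only a limit. Compound 4 is the only compound shown with a number rather than a limit: the limit of > 30000 nM in this assay, at which 3 of the 4 values shown sit.

The compounds shown leave open whether this gain is particular to methoxy or would also come with a hydroxyl, an amine or a longer alkoxy chain in the same place. They also leave open whether the exchange would have the same effect if trifluoromethyl replaced the fluoro on the remaining 4-fluorophenyl group.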